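This account rests on a few compounds, and the source may have more. Where it says the series, first, only, none or still open, it means among the compounds named here.

Measured so far:
Compound 1 `COC(=O)CC(=O)N1N=C(c2ccc(N3CCN(C)CC3)cc2)CC1c1ccc(N(C)C)cc1` – in a functional assay on MDA-MB-231 cells (Homo sapiens) for inhibition, read by sulforhodamine B assay, tested at 10 uM (a lower number here means less inhibition, a higher number more inhibition at the concentration tested (going by the name of the read-out)), compound 1 gives -0.4%.
Compound 2 `CN1CCN(c2ccc(C3=NN(S(=O)(=O)c4ccc(F)cc4)C(c4ccc(N(C)C)cc4)C3)cc2)CC1` – in this assay compound 2 gives 15.7%.

Compound 1 stands lowest of the two numbers; its nearest neighbour is compound 2, with a number 16.1 percentage points higher from compound 1 to compound 2 (beyond the scatter). That step exchanges the group on the amine nitrogen in a ring of the shared core and leaves the aryl substituents untouched.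

Compound 3 `COC(=O)CC(=O)N1N=C(c2ccc(-n3ccnc3)cc2)CC1c1ccc(N(C)C)cc1` differs from compound 1 at another place: 1H-imidazol-1-yl in place of 4-methylpiperazin-1-yl on an aromatic carbon. Among the measured compounds shown here, no measured step changes this aromatic carbon, so the single step known in this assay does not bear on it, and there is nothing to point in either direction. The working expectation is therefore a step not beyond the scatter, roughly a number 3.4 percentage points higher from compound 1 to compound 3 (within the scatter), with compound 3 staying near compound 1. For compound 3 the estimated value in this assay is 3%, expected to fall between -10% and 18%.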

Compound 3, a percentage reported as inhibition, at one concentration (the size of the read-out at that concentration, not a potency): 2.3%
Beside the measured number, compound 3's estimate is 0.7 percentage points above it; the range from low to high includes it.
By their numbers in this assay, from the lowest: compounds 1 and 3 (each within the scatter of the next); then compound 2.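

In this assay, the aromatic carbon para to a large group now has a step of its own: a number 2.7 percentage points higher from compound 1 to compound 3 (within the scatter). Replacing 4-methylpiperazin-1-yl with 1H-imidazol-1-yl, and so a six-membered non-aromatic ring with a five-membered aromatic ring, therefore does not separate the two compounds while ((methoxycarbonyl)methyl)carbonyl stays on the ring nitrogen. No measurement available here accounts for this result.

Going by these compounds, compound 1 gives -0.4% and compound 3 gives 2.3%, so it remains open whether 1H-imidazol-1-yl and 4-methylpiperazin-1-yl would also read alike with (4-fluorophenyl)sulfonyl on that nitrogen. Also open, on these data alone, is how a carboxylic acid or a primary amine on this aromatic carbon would read.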